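Removing a Ring Chloro Group in Matched Purine Pairs

The source may hold more compounds than are shown below. What is called first, only, known or untested is meant among the compounds shown, and "the series" means these compounds.

Measured compounds:
compound 1 `ClCc1ccc(Cn2cnc3nc(Cl)nc(Cl)c32)cc1`: 1650 nM
compound 2 `ClCc1ccccc1Cn1cnc2ncnc(Cl)c21`: 1650 nM
compound 3 `ClCc1ccccc1Cn1cnc2nc(Cl)nc(Cl)c21`: 1 nM

In a functional assay on RXF 393 cells (Homo sapiens) for cytotoxicity, read by sulforhodamine B assay, with a stated time of 48 h (a lower number here means a stronger inhibitor of growth, a higher number a weaker inhibitor of growth), compound 3 stands apart: the step of a 1700-fold higher number from compound 3 to compound 2 (3.22 log units; beyond the scatter) follows from hydrogen in place of chloro on an aromatic carbon. Compound 1 and compound 2 give the same number at the digits shown. How the core of compound 1 differs from that of compound 3 is not broken down here; the two share the same atoms joined differently.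

Compound 4 `ClCc1ccc(Cn2cnc3ncnc(Cl)c32)cc1` is not yet measured. It differs from compound 1 by hydrogen in place of chloro on an aromatic carbon, the same change as from compound 3 to compound 2. That earlier step was large, so a weaker result is expected for compound 4, but a smaller step of a 12-fold higher number from compound 1 to compound 4 (1.08 log units; beyond the scatter) is estimated because compound 1 already gives 1650 nM in this assay, near the top of the range seen. Compound 4 is thus expected to give about 20000 nM, estimated between 3000 nM and 200000 nM.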

Compound 4, concentration for 50% growth inhibition: 1650 nM
Beside the measured number, compound 4's estimate is 12-fold (1.08 log units) above it, and the stated range ends above it.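

Replacing chloro with hydrogen on the core of compound 1 gives no change at the digits printed from compound 1 to compound 4 (within the scatter) in this assay, so the change does not carry over with the same size from one core to the other: the same change on two cores in this assay, a 1700-fold higher number (3.22 log units; beyond the scatter) from compound 3 to compound 2 and no change at the digits printed (within the scatter) from compound 1 to compound 4, 1700-fold (3.22 log units) apart, beyond the scatter of two such steps. The size of the step on one core therefore gave no guide to its size on the other in these two matched pairs. Two pairs do not show why the results part, nor how the change would behave on a further core.

The compounds shown leave open what an amine or a methoxy group would give in place of that chloro group on either core. They also leave open whether the two cores would part in the same way in other cell lines.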